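The source may hold more compounds than are shown below. What is called first, only, known or untested is meant among the compounds shown, and "the series" means these compounds.

Measured in an ADME assay on Vero cells (Chlorocebus sabaeus) for cytotoxicity; a lower number here means that less compound is tolerated, a higher number that more compound is tolerated:

Compound 1 `CO/N=C1/C(=O)N(Cc2cn(CC(=O)N3CCN(c4cc5c(cc4F)c(=O)c(C(=O)O)cn5C4CC4)CC3)nn2)c2c(F)cccc21` gives 32 ug/mL.
Compound 2 `CCO/N=C1/C(=O)N(Cc2cn(CC(=O)N3CCN(c4cc5c(cc4F)c(=O)c(C(=O)O)cn5C4CC4)CC3)nn2)c2c(F)cccc21` gives 16 ug/mL.
Compound 3 `CO/N=C1/C(=O)N(Cc2cn(CC(=O)N3CCN(c4cc5c(cc4F)c(=O)c(C(=O)O)cn5C4CC4)CC3)nn2)c2ccc(F)cc21` gives 64 ug/mL.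

Compounds 1 and 2 differ by one change, (methyl in place of hydrogen on a saturated chain carbon bound to an oxygen on an unsaturated carbon), and this gave a 2.0-fold lower number from compound 1 to compound 2 (0.30 log units; within the scatter). Compound 3 shares the same atoms as compound 1 joined differently; the difference between the two cores is not broken down here. Its value lies within the usual scatter of that of compound 1 and beyond the scatter of that of compound 2.

Compound 4 `CCO/N=C1/C(=O)N(Cc2cn(CC(=O)N3CCN(c4cc5c(cc4F)c(=O)c(C(=O)O)cn5C4CC4)CC3)nn2)c2ccc(F)cc21` is compound 3 with the same change, (methyl in place of hydrogen on a saturated chain carbon bound to an oxygen on an unsaturated carbon), at a place described in the same words, so the change is the same. Among the compounds with values here, a step of a 2.0-fold lower number from compound 3 to compound 4 (0.30 log units; within the scatter) is expected in this assay because the one measured instance gave a 2.0-fold lower number from compound 1 to compound 2 (0.30 log units; within the scatter), a step that is itself within the scatter. Compound 4 is therefore estimated at 32 ug/mL, between 16 ug/mL and 64 ug/mL.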

Compound 4, half-maximal cytotoxic concentration: 8 ug/mL
Compound 4: middle estimate off by 4.0-fold (0.60 log units), on the high side; measured number below the stated range.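

In this assay, going from methoxy to ethoxy gave an 8.0-fold lower number from compound 3 to compound 4 (0.90 log units; beyond the scatter). The same change therefore did not carry over at the same size from one core to the other: the same change on two cores in this assay, a 2.0-fold lower number (0.30 log units; within the scatter) from compound 1 to compound 2 and an 8.0-fold lower number (0.90 log units; beyond the scatter) from compound 3 to compound 4, 4.0-fold (0.60 log units) apart, beyond the scatter of two such steps. With one pair on each core, this shows that the step measured on one core cannot simply be transferred to the other, but it does not show what in the cores sets the two steps apart or how the change would behave on a further core.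

The compounds shown leave open how a longer chain, such as propoxy, would behave in place of methoxy and ethoxy. They also leave open whether its step would differ between these two cores.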